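Swapping a Hydroxypropoxy Arm for a Nitrooxymethyl Group

The source may report more compounds than this note shows. Statements on the series, on what has been measured and on what is new or still open speak of the compounds shown alone.

Three compounds share a core and differ only in the group on the benzyl ring. In an assay for inhibition of Amine oxidase [flavin-containing] A (Homo sapiens), read by fluorescence, using microsomes, with a stated time of 30 min (a lower number here means a stronger inhibitor, a higher number a weaker inhibitor), compound 1 `Cc1c(C)c2ccc(OCC3CCN(Cc4ccc(CO)cc4)CC3)cc2oc1=O` gives 1400 nM, compound 2 `Cc1c(C)c2ccc(OCC3CCN(Cc4cccc(CO)c4)CC3)cc2oc1=O` gives 1900 nM, and compound 3 `Cc1c(C)c2ccc(OCC3CCN(Cc4cccc(OCCCO)c4)CC3)cc2oc1=O` gives 550 nM. Compound 3 is the strongest inhibitor of the three: a 2.5-fold lower number from compound 1 to compound 3 (0.41 log units; beyond the scatter) and a 3.5-fold lower number from compound 2 to compound 3 (0.54 log units; beyond the scatter), both beyond the scatter, whereas a 1.4-fold higher number from compound 1 to compound 2 (0.13 log units; within the scatter).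

Compound 4 `Cc1c(C)c2ccc(OCC3CCN(Cc4cccc(CO[N+](=O)[O-])c4)CC3)cc2oc1=O` is compound 3 with one change: (nitrooxy)methyl in place of 3-hydroxypropoxy on an aromatic carbon. For the measured compounds named here, the measured step that bears on this is the one from compound 2 to compound 3, where the longer 3-hydroxypropoxy chain replaced hydroxymethyl and lowered the number. Compound 4 returns to a one-carbon link, now carrying a nitrooxy group with no hydrogen-bond donor. Because a 3.5-fold lower number from compound 2 to compound 3 (0.54 log units; beyond the scatter) was modest, a step back toward compound 2 of similar size is expected, so compound 4 is estimated to give 1300 nM, with a range from 450 nM to 4000 nM. That estimate corresponds to an expected step of a 2.4-fold higher number from compound 3 to compound 4 (0.37 log units; beyond the scatter) in this assay.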

Compound 4, half-maximal inhibitory concentration: 230 nM
The estimate for compound 4 lay 5.7-fold (0.75 log units) above the measured number; measured number below the stated range.
By their numbers in this assay, from the lowest: compound 4; then compound 3; then compounds 1 and 2 (each within the scatter of the next).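

Putting (nitrooxy)methyl in place of 3-hydroxypropoxy gives a 2.4-fold lower number from compound 3 to compound 4 (0.38 log units; beyond the scatter) in this assay so a longer chain ending in a hydroxyl is not required for a low number at this aromatic carbon. The clearest comparison keeps the one-carbon link and changes only the end of the group: nitro in place of hydrogen on the oxygen gives an 8.3-fold lower number from compound 2 to compound 4 (0.92 log units; beyond the scatter) and shows that a hydroxymethyl group need not be replaced by a longer arm for the number to fall. The step of a 6.1-fold lower number from compound 1 to compound 4 (0.78 log units; beyond the scatter) points the same way, although the group's place on the ring changes there as well.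

Going by these compounds, whether a 3-(nitrooxy)propoxy arm, a methoxymethyl group or an aminomethyl group would give a similar number remains open. Nothing shown here explains the lower number of compound 4.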